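This account rests on a few compounds, and the source may have more. Where it says the series, first, only, none or still open, it means among the compounds named here.

Measured in an assay on HEK-293T cells for inhibition of diacylglycerol lipase-alpha (Homo sapiens), read by colorimetric assay; on this read-out lower numbers stand for stronger inhibition and higher numbers for weaker inhibition:
Compound 1, `O=C(CCCCCc1ccccc1)c1nc2cc([N+](=O)[O-])ccc2o1`, gives 891 nM.
Compound 2, `CS(=O)(=O)c1coc(C(=O)CCCCCCc2ccccc2)n1`, gives 389 nM.

Of these two numbers compound 2 has the lower one, so in this assay it inhibits more strongly than compound 1, and the gap between the two lies beyond the usual scatter of repeated measurements, so the order can be trusted. Compound 3, `CNC(=O)c1coc(C(=O)CCCCCCc2ccccc2)n1`, has not yet been measured. It keeps the whole chain and the ring of compound 2 and differs from it in a single place: methylcarbamoyl in place of methylsulfonyl on an aromatic carbon. Going by the values given here, nothing among the measured compounds shows how such an exchange at this position moves the read-out, so any expectation has to rest on the change itself rather than on a measured step. A modest step toward weaker inhibition is expected, a 1.4-fold higher number from compound 2 to compound 3 (0.15 log units; within the scatter), although it could well stay within the scatter. Compound 3 is therefore estimated at 550 nM in this assay, with a plausible range from 140 nM to 2200 nM.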

Compound 3, half-maximal inhibitory concentration: > 10000 nM
Compound 3 ended at the assay's limit; the forecaster's own chance of this, stated with the estimate: 5%; middle value at least 18-fold (1.25 log units) away from the limit.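

Exchanging methylsulfonyl for methylcarbamoyl on the aromatic carbon next to the ring nitrogen, with the chain and the rest of the molecule unchanged, gives an at least 25-fold higher number from compound 2 to compound 3 (1.41 log units; beyond the scatter) and so shows that inhibition depends strongly on which group sits at this position. The two groups hold equally many heavy atoms, so that count alone does not decide the outcome; methylcarbamoyl differs in its atoms and brings a hydrogen-bond donor that methylsulfonyl lacks, but this single pair cannot show which difference matters. On these data alone, for compound 3 the entry of > 10000 nM in this assay is a limit of the assay and not a number, so the full size of the step stays unknown: the limit of > 10000 nM in this assay, at which 1 of the 3 values shown sits.

As far as these compounds go, it remains open whether other groups at this position, such as a nitrile, a carboxylic acid or a plain hydrogen, would behave like methylsulfonyl or like methylcarbamoyl. From the compounds shown here alone, it is also open whether an ethylsulfonyl group would keep the inhibition and whether a shorter or longer chain would change the effect of this exchange.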